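Moving the Fluorine: 3-Fluorobenzyl to 4-Fluorobenzyl

A few compounds are considered here, and "the series" means these few. Any claim that something is new, unique, unknown or untested is made for them only; others in the source may bear on it.

Of the compounds shown here, three with a shared core have been measured in a functional assay, read by spectrophotometry, with a stated time of 30 min; on this read-out lower numbers stand for stronger inhibition and higher numbers for weaker inhibition. Compound 1 `COc1ccc(CN2CCC(CCNC(=O)/C=C/c3cc(C(C)(C)C)c(O)c(C(C)(C)C)c3)CC2)cc1` gives 61200 nM, compound 2 `CC(C)(C)c1cc(/C=C/C(=O)NCCC2CCN(Cc3ccccc3F)CC2)cc(C(C)(C)C)c1O` gives 55900 nM, and compound 3 `CC(C)(C)c1cc(/C=C/C(=O)NCCC2CCN(Cc3cccc(F)c3)CC2)cc(C(C)(C)C)c1O` gives 55200 nM. Compound 3 therefore stands level with the other two, since repeat measurements of this kind would not reliably separate these numbers.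

Compound 4 `CC(C)(C)c1cc(/C=C/C(=O)NCCC2CCN(Cc3ccc(F)cc3)CC2)cc(C(C)(C)C)c1O` has the same atoms as compound 3, joined differently: 4-fluorophenyl in place of 3-fluorophenyl on a saturated chain carbon bound to an amine nitrogen in a ring. The change is 4-fluorophenyl in place of 3-fluorophenyl, on a saturated chain carbon bound to an amine nitrogen in a ring.

Going by the values given here, the closest precedent is the exchange of 2-fluorophenyl for 3-fluorophenyl at that place, which gave a 1.0-fold lower number from compound 2 to compound 3 (0.01 log units; within the scatter). Replacing 4-methoxyphenyl gave a 1.1-fold lower number from compound 1 to compound 2 (0.04 log units; within the scatter) with 2-fluorophenyl and a 1.1-fold lower number from compound 1 to compound 3 (0.04 log units; within the scatter) with 3-fluorophenyl. Among the compounds with values here, all three steps lie within the scatter, although no measured compound yet carries 4-fluorophenyl. On this evidence, no change beyond the scatter is expected in this assay, in either direction, and the expected step is a 1.0-fold higher number from compound 3 to compound 4 (0.01 log units; within the scatter).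

The estimated value for compound 4 is 56000 nM, with an expected range of 38000 nM to 82000 nM.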

Compound 4, half-maximal inhibitory concentration: 57500 nM
Estimate against measurement, compound 4: 1.0-fold (0.01 log units) below; measured number inside the range.
By their numbers in this assay, from the lowest: compounds 3, 2, 4 and 1 (each within the scatter of the next).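

With 4-fluorophenyl now in the series, all three fluorophenyl groups can be compared on the saturated chain carbon bound to an amine nitrogen in a ring, and this assay does not separate them: the change gives a 1.0-fold higher number from compound 3 to compound 4 (0.02 log units; within the scatter) and, for the other fluorinated compound, a 1.0-fold higher number from compound 2 to compound 4 (0.01 log units; within the scatter). Going by these compounds alone, the series also gains its simplest comparison with the methoxy compound, since only one small group differs, with fluoro in place of methoxy on an aromatic carbon, and this gives a 1.1-fold lower number from compound 1 to compound 4 (0.03 log units; within the scatter). All four compounds therefore stand level at this place, but no measurement shown explains why these changes leave the read-out within the scatter.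

What remains open is whether any group at this place can move the read-out beyond the scatter, since fluoro and methoxy are the only substituents shown on this aromatic ring. A carboxylic acid, a primary amine or a trifluoromethyl group on the ring, or a longer chain linking the ring to the amine nitrogen, would test whether this part of the molecule matters in this assay at all.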